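One Carbon Longer on the Ester Arm

The compounds below may be only part of what the source reports. "The series", "measured", "known", "first", "only" and "open" are said of these compounds alone.

Compound 2 `COC(=O)CNC1=CS(=O)(=O)O[C@@]12[C@@H](CO[Si](C)(C)C(C)(C)C)O[C@@H](n1cc(C)c(=O)n(C)c1=O)[C@@H]2O[Si](C)(C)C(C)(C)C` carries a (methoxycarbonyl)methyl group on its amine. In a functional assay on HEL cells (Homo sapiens) (a lower number here means that less compound is tolerated, a higher number that more compound is tolerated), compound 2 gives 160000 nM, the higher of the two plain numbers available, though its companion compound 1 `Cc1cn([C@@H]2O[C@H](CO[Si](C)(C)C(C)(C)C)[C@@]3(OS(=O)(=O)C=C3NCC(=O)O)[C@H]2O[Si](C)(C)C(C)(C)C)c(=O)n(C)c1=O` gives 136000 nM, and the step of a 1.2-fold higher number from compound 1 to compound 2 (0.07 log units; within the scatter) separates them. Compound 3 `COC(=O)C(=O)CNC1=CS(=O)(=O)O[C@@]12[C@@H](CO[Si](C)(C)C(C)(C)C)O[C@@H](n1cc(C)c(=O)n(C)c1=O)[C@@H]2O[Si](C)(C)C(C)(C)C` reaches only a limit of this assay, > 200000 nM. Compound 4 `COC(=O)CCNC1=CS(=O)(=O)O[C@@]12[C@@H](CO[Si](C)(C)C(C)(C)C)O[C@@H](n1cc(C)c(=O)n(C)c1=O)[C@@H]2O[Si](C)(C)C(C)(C)C` differs from compound 2 by (methoxycarbonyl)methyl in place of methoxycarbonyl on a saturated chain carbon bound to an amine nitrogen. The two measured changes at this same end of the chain were both small: a 1.2-fold higher number from compound 1 to compound 2 (0.07 log units; within the scatter) and an at least 1.2-fold higher number from compound 2 to compound 3 (0.09 log units; that floor lies within the scatter). Because one of three values already sits at the limit of > 200000 nM in this assay, at which 1 of the 3 values shown sits, a limit is also possible. No shift beyond the scatter is expected: a 1.1-fold higher number from compound 2 to compound 4 (0.03 log units; within the scatter). Compound 4 is therefore estimated at 170000 nM, likely between 90000 nM and 320000 nM.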

Compound 4, half-maximal cytotoxic concentration: 94000 nM
Estimate against measurement, compound 4: 1.8-fold (0.26 log units) above; the measured number falls inside the stated range.
By their numbers in this assay, from the lowest: compounds 4, 1 and 2 (each within the scatter of the next). At a limit, above all of these: compound 3.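

In this assay, the longer 2-(methoxycarbonyl)ethyl chain stays within the scatter of both the shorter ester (a 1.7-fold lower number from compound 2 to compound 4 (0.23 log units; within the scatter)) and the carboxy chain (a 1.4-fold lower number from compound 1 to compound 4 (0.16 log units; within the scatter)). Only the comparison with the (methoxycarbonyl)carbonyl chain goes beyond the scatter (an at least 2.1-fold lower number from compound 3 to compound 4 (0.32 log units; beyond the scatter)). The value of compound 3 is a limit, so the true size of that step stays unknown: the limit of > 200000 nM in this assay, at which 1 of the 4 values shown sits.

The compounds shown leave open how a carboxylic acid in place of the ester on the 2-(methoxycarbonyl)ethyl chain would compare. They also leave open the effect of an amine at the chain end or a still longer chain.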